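The compounds below may be only part of what the source reports. "The series", "measured", "known", "first", "only" and "open" are said of these compounds alone.

In a functional assay on MCF7 cells (Homo sapiens) for cytotoxicity, read by MTT assay, with a stated time of 24 h (a higher number here means a weaker inhibitor, a lower number a stronger inhibitor), compound 2 `O=C(NC(=S)Nc1nc2cc([N+](=O)[O-])ccc2s1)N1CCOCC1` gives 31000 nM, while compound 3 `O=C(NC(=S)Nc1nc2cc([N+](=O)[O-])ccc2s1)c1ccccc1` gives 41600 nM. These two stand level, a 1.3-fold higher number from compound 2 to compound 3 (0.13 log units; within the scatter) being within the scatter. Compound 1 `CCCCC(=O)NC(=S)Nc1nc2cc([N+](=O)[O-])ccc2s1` reads > 100000 nM, which is a limit of the assay. Compound 4 `O=C(NC(=S)Nc1nc2ccccc2s1)N1CCOCC1` differs from compound 2 at another place, with hydrogen in place of nitro on an aromatic carbon. For the measured compounds named here, no measured step touches that place. The nearest guides for size are changes on the carbonyl carbon, an at least 3.2-fold lower number from compound 1 to compound 2 (0.50 log units; beyond the scatter) and an at least 2.4-fold lower number from compound 1 to compound 3 (0.38 log units; beyond the scatter), both at least modest. A similarly modest move towards a higher number in this assay is therefore expected, though its direction is uncertain, and the estimated step is a 1.5-fold higher number from compound 2 to compound 4 (0.16 log units; within the scatter). For compound 4 the estimated value is 45000 nM, with an expected range of 17000 nM to 100000 nM.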

Compound 4, half-maximal inhibitory concentration: 29300 nM
The estimate for compound 4 lay 1.5-fold (0.19 log units) above the measured number; low and high end bracket the measured number.
By their numbers in this assay, from the lowest: compounds 4, 2 and 3 (each within the scatter of the next). At a limit, above all of these: compound 1.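

In this assay hydrogen in place of nitro on this aromatic carbon gives a 1.1-fold lower number from compound 2 to compound 4 (0.02 log units; within the scatter) and so leaves the two compounds level. This is the first step shown at this place on the core, and with morpholin-4-yl on the carbonyl carbon the nitro group proves dispensable for this reading. Nothing given here bears on why this step is so small.

Going by these compounds, whether hydrogen and nitro also stand level with phenyl or butyl on the carbonyl carbon remains open. So does the outcome with an amine or a carboxylic acid at this aromatic carbon.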